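Exchanging a Hydroxyethyl Side Chain for Methyl in a Weak Series

The source may hold more compounds than are shown below. What is called first, only, known or untested is meant among the compounds shown, and "the series" means these compounds.

Compound 1, `CC[C@H](C)[C@@H](NC(=O)Cn1cc(C2=C(c3c[nH]c4ccccc34)C(=O)N(C)C2=O)c2ccccc21)C(=O)OC`. In a functional assay on Bel-7402 cells (Homo sapiens) for cytotoxicity, read by MTT assay, with a stated time of 24 h (on this read-out lower numbers stand for stronger inhibition and higher numbers for weaker inhibition), compound 1 gives > 100000 nM, which is a limit of the assay rather than a measured number.
Compound 2, `COC(=O)[C@H](NC(=O)Cn1cc(C2=C(c3c[nH]c4ccccc34)C(=O)N(C)C2=O)c2ccccc21)[C@@H](C)O`. In this assay compound 2 gives > 100000 nM, again only a limit of the assay.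

Compound 2 therefore stands at the edge of what this assay can report, and no true number is known for it. The step that the two limits leave unreadable from compound 1 to compound 2 is unreadable because both of its ends rest at the limit of > 100000 nM in this assay, at which 2 of the 2 values shown sit.

Compound 3, `COC(=O)[C@@H](C)NC(=O)Cn1cc(C2=C(c3c[nH]c4ccccc34)C(=O)N(C)C2=O)c2ccccc21`, has not yet been measured. It differs from compound 2 in one place: methyl in place of 1-hydroxyethyl on a saturated chain carbon bound to an amide-type nitrogen and a carbonyl carbon. Within the data shown here, no measured step bears directly on this change, and the only step that exists, a step that the two limits leave unreadable from compound 1 to compound 2, gives neither a size nor a direction. Both measured compounds reach only the limit, so a sizeable gain for compound 3 cannot be inferred from them.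

The step of a number no higher from compound 2 to compound 3 (the limit leaves the size open) is therefore expected to be none beyond the scatter, with a limit again the most likely report.

Compound 3 is estimated at 100000 nM, with a range from 30000 nM to 300000 nM.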

Compound 3, half-maximal inhibitory concentration: 9340 nM
Estimate against measurement, compound 3: 11-fold (1.03 log units) above; measured number below the stated range.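

In this assay, this place on the chain, the saturated carbon bound to an amide-type nitrogen and a carbonyl carbon, now proves able to move the read-out: methyl in place of 1-hydroxyethyl gives an at least 10-fold lower number from compound 2 to compound 3 (1.02 log units; beyond the scatter), and methyl in place of sec-butyl gives an at least 10-fold lower number from compound 1 to compound 3 (1.02 log units; beyond the scatter). The gain appears against both a side chain with a hydroxy group and one made only of carbon and hydrogen, so in these three compounds it does not depend on removing the hydroxy group alone, while the step between compound 1 and compound 2 cannot be read. Both readable steps give only a minimum size, because each starts from a compound that sits at a limit: the limit of > 100000 nM in this assay, at which 2 of the 3 values shown sit.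

On these data alone, what stays open is how the read-out runs between methyl and the larger side chains, for instance with an ethyl or an unbranched propyl chain at this place, and whether a bare hydrogen there would go further than methyl. Also open, as far as these compounds go, is whether the gain would survive a carboxylic acid in place of the methyl ester.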